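Thiophene to Chlorophenyl on the Sulfonyl Sulfur

This account rests on a few compounds, and the source may have more. Where it says the series, first, only, none or still open, it means among the compounds named here.

Three sulfonamides were tested in an assay on cells for inhibition of HSP60/HSP10 (Homo sapiens), with a stated time of 60 min; a lower number here means a stronger inhibitor, a higher number a weaker inhibitor. Compound 1 `O=S(=O)(Nc1ccc(-c2nc3ccccc3o2)cc1)c1cccs1` carries a thiophen-2-yl group on its sulfonyl sulfur, and in this assay compound 1 gives 63000 nM. Compound 2 `O=S(=O)(Nc1ccc(-c2nc3ccccc3o2)cc1)c1ccc(F)c(C(F)(F)F)c1` gives 28000 nM in this assay. Of the two numbers obtained, compound 1 has the higher one, so it is the weaker inhibitor of the pair, and its gap to compound 2 lies beyond the usual scatter of repeated measurements. Compound 3 `Cc1ccccc1S(=O)(=O)Nc1ccc2oc(-c3ccccc3)nc2c1` gives only a limit in this assay, > 100000 nM, so no number is known for it.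

Compound 4 `O=S(=O)(Nc1ccc(-c2nc3ccccc3o2)cc1)c1cccc(Cl)c1` has not yet been measured. It differs from compound 1 in one place: 3-chlorophenyl in place of thiophen-2-yl on a sulfonyl sulfur. Among the measured compounds shown here, no measured pair shares exactly this change, so its effect can only be estimated. Compound 2, which also carries a phenyl-based group on the sulfonyl sulfur, sits at 28000 nM, and compound 4 is expected to fall in a similar region. The step of a 2.1-fold lower number from compound 1 to compound 4 (0.32 log units; beyond the scatter) is therefore expected to be a moderate drop in the number. The estimate for compound 4 is 30000 nM, with a likely range from 10000 nM to 90000 nM.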

Compound 4, half-maximal inhibitory concentration: 54000 nM
Compound 4: middle estimate off by 1.8-fold (0.26 log units), on the low side; low and high end bracket the measured number.
By their numbers in this assay, from the lowest: compounds 2, 4 and 1 (each within the scatter of the next, the first and the last beyond it). At a limit, above all of these: compound 3.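

Placing 3-chlorophenyl instead of thiophen-2-yl on the sulfonyl sulfur gives a 1.2-fold lower number from compound 1 to compound 4 (0.07 log units; within the scatter) in this assay, so the two groups cannot be told apart in this assay, even though one is a five-membered aromatic ring with a hetero atom and the other a six-membered aromatic ring of carbon only. Compound 4 has no hydrogen-bond acceptor in this group, so an acceptor here is not needed to keep the number in this range. Nothing measured here accounts for the result.

Still open, from the compounds shown here alone, is what a plain phenyl, a 4-chlorophenyl or a phenyl bearing an amine or a carboxylic acid would do at this position. Equally open, going by these compounds, is whether a cyclohexyl ring or a short alkyl chain on the sulfonyl sulfur would keep the number in this range.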